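The source may hold more compounds than are shown below. What is called first, only, known or untested is meant among the compounds shown, and "the series" means these compounds.

Measured so far in a functional assay on HUVEC cells (Homo sapiens), read by scintillation counting and thymidine incorporation, with a stated time of 24 h; on this read-out lower numbers stand for stronger inhibition and higher numbers for weaker inhibition:

Compound 1, `CCC(C)n1ncn(-c2ccc(N3CCN(c4ccc(OC[C@@H]5CO[C@@](CN6CCNCC6)(c6ccc(Cl)cc6Cl)O5)cc4)CC3)cc2)c1=O`: 608 nM
Compound 2, `CCC(C)n1ncn(-c2ccc(N3CCN(c4ccc(OC[C@@H]5CO[C@@](Cn6ccnc6C)(c6ccc(Cl)cc6Cl)O5)cc4)CC3)cc2)c1=O`: 173 nM

For the measured compounds named here, compound 2 stands at the lowest of the two numbers seen; the only other compound, compound 1, sits at a higher number, and that gap was found as a 3.5-fold lower number from compound 1 to compound 2 (0.55 log units; beyond the scatter). Going by the values given here, the one change recorded so far is the swap of the group on the saturated chain carbon, a piperazin-1-yl giving way to a 2-methyl-1H-imidazol-1-yl.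

Compound 3, `CCC(C)n1ncn(-c2ccc(N3CCN(c4ccc(OC[C@@H]5CO[C@@](Cn6ccnc6-c6ccccc6)(c6ccc(Cl)cc6Cl)O5)cc4)CC3)cc2)c1=O`, keeps the whole of compound 2 and alters only the small group on the imidazole ring: phenyl in place of methyl on an aromatic carbon. Among the compounds with values here, no measured pair shows this kind of change, a methyl growing into a phenyl on an aromatic carbon, so the step from compound 1 to compound 2 does not bear on it directly; it shows only that this part of the molecule can be altered without losing activity. With nothing to point either way, compound 3 is expected to land close to compound 2, with a step of about a 1.2-fold higher number from compound 2 to compound 3 (0.06 log units; within the scatter), within the usual scatter. Compound 3 is therefore estimated at 200 nM, with a range from 60 nM to 650 nM.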

Compound 3, half-maximal inhibitory concentration: 136 nM
The estimate for compound 3 lay 1.5-fold (0.17 log units) above the measured number; measured number inside the range.
By their numbers in this assay, from the lowest: compounds 3 and 2 (each within the scatter of the next); then compound 1.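

In this assay, the swap of methyl for phenyl reads as a 1.3-fold lower number from compound 2 to compound 3 (0.10 log units; within the scatter), which lies within the usual scatter, so on this aromatic carbon, between two ring nitrogen atoms, a group of 6 heavy atoms with its own six-membered aromatic ring cannot be told apart from a group of 1 heavy atom. The earlier compounds shown here showed only that 2-methyl-1H-imidazol-1-yl could take the place of piperazin-1-yl, whereas 2-phenyl-1H-imidazol-1-yl now does the same, at a 4.5-fold lower number from compound 1 to compound 3 (0.65 log units; beyond the scatter), a difference beyond the scatter, so the gap from compound 1 does not rest on the methyl alone. Nothing at hand explains why these two groups read alike in this position.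

With only methyl and phenyl at this carbon, no trend with group size can be drawn from these results. As far as these compounds go, it remains open how a plain hydrogen, a longer chain such as n-butyl, an amine such as dimethylamino, or a phenyl carrying a carboxylic acid would read at the same place.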